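This account rests on a few compounds, and the source may have more. Where it says the series, first, only, none or still open, it means among the compounds named here.

In an ADME assay on Vero cells (Chlorocebus sabaeus) for cytotoxicity, read by resazurin assay, with a stated time of 72 h (on this read-out higher numbers stand for weaker inhibition and lower numbers for stronger inhibition), compound 1 `COc1ccc(C(=O)CCN2CCN(c3ccc([N+](=O)[O-])cc3)CC2)cc1` gives 587000 nM, compound 2 `O=C(CCN1CCN(c2ccc([N+](=O)[O-])cc2)CC1)c1ccc(F)c(Br)c1` gives 256000 nM, and compound 3 `O=C(CCN1CCN(c2ccc(C(F)(F)F)cc2)CC1)c1ccc(Cl)c(F)c1` gives 74300 nM. Compound 3 holds the lowest of these three numbers, and its gaps to both others lie beyond the scatter. Compound 4 `O=C(CCN1CCN(c2ccc([N+](=O)[O-])cc2)CC1)c1ccc(Cl)c(F)c1` differs from compound 3 in one place, with nitro in place of trifluoromethyl on an aromatic carbon. Among the compounds with values here, no measured step makes this exchange. Within the data shown here, the only measured step, a 2.3-fold lower number from compound 1 to compound 2 (0.36 log units; beyond the scatter), is modest and concerns a different place, the group on the carbonyl carbon. Its size suggests that changes there need not move the number far. Compound 1 and compound 2 both carry the nitro group, and the lower of the two, compound 2 at 256000 nM, still stands above compound 3. A moderate move to a higher number in this assay is therefore expected, though this rests on indirect evidence. The expected change is a 2.6-fold higher number from compound 3 to compound 4 (0.41 log units; beyond the scatter). For compound 4 the estimated value is 190000 nM, with an expected range of 85000 nM to 420000 nM.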

Compound 4, half-maximal inhibitory concentration: 89200 nM
Estimate against measurement, compound 4: 2.1-fold (0.33 log units) above; measured number inside the range.
By their numbers in this assay, from the lowest: compounds 3 and 4 (each within the scatter of the next); then compound 2; then compound 1.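

In this assay, within the data shown here, the exchange of trifluoromethyl for nitro on the aromatic carbon para to a large group, tested here for the first time, gives a 1.2-fold higher number from compound 3 to compound 4 (0.08 log units; within the scatter), so with 4-chloro-3-fluorophenyl on the carbonyl carbon the two groups cannot be told apart. With nitro held in place, the group on the carbonyl carbon does move the number, with a 2.9-fold lower number from compound 2 to compound 4 (0.46 log units; beyond the scatter) and a 6.6-fold lower number from compound 1 to compound 4 (0.82 log units; beyond the scatter), both modest but beyond the scatter. No supporting measurement is at hand to account for either result.

On these data alone, whether trifluoromethyl and nitro stay this close with 3-bromo-4-fluorophenyl or 4-methoxyphenyl on the carbonyl carbon remains open. So does what an amine or a carboxylic acid on that aromatic carbon, or a longer chain leading to the carbonyl, would do to the number.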